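Dropping a chloro from the core of compound 1

The compounds below may be only part of what the source reports. "The series", "measured", "known", "first", "only" and "open" are said of these compounds alone.

Compound 1, `ClCc1cccc(Cn2cnc3c(Cl)nc(Cl)nc32)c1`: 3380 nM
Compound 2, `Nc1nc(Cl)c2ncn(Cc3ccc(CCl)cc3)c2n1`: 2950 nM

In a functional assay on MOLT-4 cells (Homo sapiens) for cytotoxicity, read by sulforhodamine B assay, with a stated time of 48 h (a lower number here means a stronger inhibitor of growth, a higher number a weaker inhibitor of growth), compound 1 gives 3380 nM, the highest of the two numbers, with compound 2 at 2950 nM sitting within the scatter of it. Compound 3, `ClCc1cccc(Cn2cnc3c(Cl)ncnc32)c1`, differs from compound 1 by hydrogen in place of chloro on an aromatic carbon. Going by the values given here, no pair of measured compounds shows this step, so its size is open; a modest rise in the number is expected, but none clearly beyond the scatter. The step expected from compound 1 to compound 3 in this assay is a 1.3-fold higher number from compound 1 to compound 3 (0.12 log units; within the scatter). Compound 3 is estimated at 4500 nM, ranging from 1500 nM to 14000 nM.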

Compound 3, concentration for 50% growth inhibition: 15900 nM
Beside the measured number, compound 3's estimate is 3.5-fold (0.55 log units) below it; measured number above the stated range.
By their numbers in this assay, from the lowest: compounds 2 and 1 (each within the scatter of the next); then compound 3.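

In this assay, hydrogen in place of the chloro between two ring nitrogen atoms gives a 4.7-fold higher number from compound 1 to compound 3 (0.67 log units; beyond the scatter) and so shows that growth inhibition in these cells responds to what sits at this position. Compound 1 and compound 2 differ in more than one place, so they could not show this. Nothing measured here accounts for the size of the step.

Going by these compounds, whether a fluoro or a methoxy group at this position would match the chloro remains open. So does whether the step holds when the chloromethyl group sits elsewhere on the benzyl ring.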